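Working notes: cytotoxicity limits across a small fluorinated series

The source may hold more compounds than are shown below. What is called first, only, known or untested is meant among the compounds shown, and "the series" means these compounds.

Three compounds of the series have been run in an ADME assay on Vero cells (Chlorocebus sabaeus) for cytotoxicity, with a stated time of 72 h; a lower number here means a stronger inhibitor, a higher number a weaker inhibitor. Among the compounds with values here, compound 1, `O=[N+]([O-])c1cn2c(n1)OC[C@@H](OCc1ccn(-c3ccc(F)cc3)n1)C2`, is the first of them. In this assay compound 1 gives only a limit, > 128000 nM, not a number. Compound 2, `O=[N+]([O-])c1cn2c(n1)OC[C@@H](OCc1ccn(-c3ccc(OC(F)(F)F)cc3)n1)C2`, carries the change trifluoromethoxy in place of fluoro on an aromatic carbon relative to compound 1. In this assay compound 2 likewise gives only a limit, > 128000 nM. The resulting step that the two limits leave unreadable from compound 1 to compound 2 cannot be read in size because of the limit of > 128000 nM in this assay, at which 3 of the 3 values shown sit.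

Compound 3, `O=[N+]([O-])c1cn2c(n1)OC[C@@H](OCc1cnn(-c3ccc(F)cc3)n1)C2`, has a core that differs from the core of compound 1; the difference between the two cores is not broken down here. In this assay compound 3 also gives only a limit, > 128000 nM.

Compound 4, `O=[N+]([O-])c1cn2c(n1)OC[C@@H](OCc1cnn(-c3ccc(OC(F)(F)F)cc3)n1)C2`, has not yet been measured. It differs from compound 3 by trifluoromethoxy in place of fluoro on an aromatic carbon, the same change as that from compound 1 to compound 2, made at a place described in the same words. With all three measured values sitting at the limit because of the limit of > 128000 nM in this assay, at which 3 of the 3 values shown sit, the measured step gives no number to carry over, and the expectation for compound 4 is a step that the limit leaves unreadable from compound 3 to compound 4 that again stays unreadable at the limit. Compound 4 is therefore estimated at 200000 nM in this assay, within 100000 nM to 400000 nM, most likely reported as a limit rather than a number.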

Compound 4, half-maximal inhibitory concentration: > 128000 nM
Compound 4: a limit, no number (the forecaster's own chance of this, stated with the estimate: 90%); the middle value does not contradict the limit.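

No size can be read for the change from compound 3 to compound 4, because both give only a limit and not a number: the limit of > 128000 nM in this assay, at which 4 of the 4 values shown sit.

The compounds shown leave open whether trifluoromethoxy in place of fluoro on an aromatic carbon alters the read-out of this assay at all, and what number any of the four compounds would give.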